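This account rests on a few compounds, and the source may have more. Where it says the series, first, only, none or still open, it means among the compounds named here.

Measured so far in an assay on HEK293 cells for binding affinity to D(4) dopamine receptor (Homo sapiens), read by radioligand binding; a higher number here means a weaker inhibitor, a lower number a stronger inhibitor:
compound 1 `COc1ccccc1N1CCN(CCCCNC(=O)C(C)(C)C)CC1` gives 12.6 nM
compound 2 `CC(C)(C)C(=O)NCCCCN1CCN(c2ccccc2Cl)CC1` gives 79.4 nM
compound 3 `COc1ccc(N2CCN(CCCCNC(=O)C(C)(C)C)CC2)cc1` gives 316 nM

Compound 2 stands second highest of the three numbers. Its nearest neighbour is reached by the step of a 4.0-fold higher number from compound 2 to compound 3 (0.60 log units; beyond the scatter), its furthest by the step of a 6.3-fold higher number from compound 1 to compound 2 (0.80 log units; beyond the scatter).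

Compound 4 `CC(C)(C)C(=O)NCCCCN1CCN(c2ccc(Br)cc2)CC1` differs from compound 2 in one place: 4-bromophenyl in place of 2-chlorophenyl on an amine nitrogen in a ring. Among the measured compounds shown here, two measured steps bear on this change. The exchange of 2-methoxyphenyl for 4-methoxyphenyl, a 25-fold higher number from compound 1 to compound 3 (1.40 log units; beyond the scatter), and the exchange of 2-chlorophenyl for 4-methoxyphenyl, a 4.0-fold higher number from compound 2 to compound 3 (0.60 log units; beyond the scatter), both raise the number beyond the scatter. For the measured compounds named here, no measured pair separates the change of halogen from the change of position on the ring, and no bromo compound has been measured, so the size of the step for compound 4 rests on these two comparisons alone. A rise beyond the scatter in this assay is therefore expected, more likely on the modest side because a 4.0-fold higher number from compound 2 to compound 3 (0.60 log units; beyond the scatter) is the closer comparison. Compound 4 is estimated at 250 nM, within a range of 80 nM to 800 nM. For compound 4 this amounts to an expected step of a 3.1-fold higher number from compound 2 to compound 4 (0.50 log units; beyond the scatter).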

Compound 4, inhibition constant: 31.6 nM
For compound 4 the middle estimate is 7.9-fold (0.90 log units) above the measured one; the whole stated range lies above it.
By their numbers in this assay, from the lowest: compound 1; then compound 4; then compound 2; then compound 3.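

In this assay a 4-substituted phenyl on the ring nitrogen does not by itself raise the number: 4-bromophenyl in place of 2-chlorophenyl gives a 2.5-fold lower number from compound 2 to compound 4 (0.40 log units; beyond the scatter), opposite in direction to the rise seen with 4-methoxyphenyl. The direction therefore depends on the group carried as well as on the group replaced, since 4-bromophenyl in place of 2-methoxyphenyl still gives a 2.5-fold higher number from compound 1 to compound 4 (0.40 log units; beyond the scatter), and compound 1 keeps the lowest number of the four. With the place on the phenyl held, exchanging the methoxy group for a bromo group gives a 10-fold lower number from compound 3 to compound 4 (1.00 log units; beyond the scatter), so in this pair the identity of the group alone accounts for a step beyond the scatter.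

How much of the step from 2-chlorophenyl to 4-bromophenyl belongs to the halogen and how much to its place on the phenyl stays unresolved, as does whether a nitrile or a carboxylic acid on the phenyl would track with bromo or with methoxy. Nothing measured on these compounds gives a cause for any of these steps.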